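The source may hold more compounds than are shown below. What is called first, only, known or untested is meant among the compounds shown, and "the series" means these compounds.

Compound 1 `Nc1ccccc1NC(=O)c1ccc(CSC(=S)N2CCc3ccccc32)cc1` stands second highest of the three numbers in a functional assay on A-375 cells (Homo sapiens) for antiproliferative activity, read by CCK-8 assay, with a stated time of 72 h, tested at 8 uM (a lower number here means a weaker effect, a higher number a stronger effect of the compound at the concentration tested), within the scatter of both neighbours: compound 1 gives 85.4%, compound 2 `Nc1ccccc1NC(=O)c1ccc(CSC(=S)N2CCN(c3cccnc3)CC2)cc1` gives 88.8%, and compound 3 `Nc1ccccc1NC(=O)c1ccc(CSC(=S)N2CCN(c3ccc(F)cc3)CC2)cc1` gives 76.3%. Going by the values given here, the one step between measured compounds, a number 12.5 percentage points lower from compound 2 to compound 3 (beyond the scatter), is modest and concerns the amine nitrogen in a ring, not the thiocarbonyl carbon. Compound 4 `CCN(Cc1ccncc1)C(=S)SCc1ccc(C(=O)Nc2ccccc2N)cc1` differs from compound 1 by ethyl((pyridin-4-yl)methyl)amino in place of 2,3-dihydro-1H-indol-1-yl on a thiocarbonyl carbon. Among the compounds with values here, no measured step changes the group on the thiocarbonyl carbon, so nothing bears directly on this change; the span of the three values is the only guide to its likely size. For compound 4 in this assay no step beyond the scatter is expected, a number 3.4 percentage points lower from compound 1 to compound 4 (within the scatter), with an estimate of 82% in the range 66% to 93%.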

Compound 4, a percentage reported as inhibition, at one concentration (the size of the read-out at that concentration, not a potency): 86.2%
For compound 4 the middle estimate is 4.2 percentage points below the measured one, within the range that was stated.
By their numbers in this assay, from the lowest: compounds 3, 1, 4 and 2 (each within the scatter of the next, the first and the last beyond it).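

In this assay, the first change shown on a thiocarbonyl carbon, ethyl((pyridin-4-yl)methyl)amino in place of 2,3-dihydro-1H-indol-1-yl, gives a number 0.8 percentage points higher from compound 1 to compound 4 (within the scatter). This position therefore accepts an entering group with one six-membered aromatic ring and a hydrogen-bond acceptor without a step beyond the scatter, at this single concentration. No evidence accounts for this result. From the compounds shown here alone, whether a morpholine or a plain diethylamino group, with no aromatic ring, would behave alike remains open. A read-out at one concentration also leaves any potency difference between these two compounds unresolved.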